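The compounds below may be only part of what the source reports. "The series", "measured", "known", "first", "only" and "open" are said of these compounds alone.

Measured so far in a functional assay on HCT-116 cells (Homo sapiens) for antiproliferative activity, read by MTT assay, with a stated time of 48 h; on this read-out lower numbers stand for stronger inhibition and higher numbers for weaker inhibition:
Compound 1 `N#CC1=C(N)Oc2c(c3nc4ccccc4nc3c3ccccc23)C12C(=O)N(Cc1cnnn1-c1ccc(S(N)(=O)=O)cc1)c1ccccc12` gives 31200 nM.
Compound 2 `Cc1ccc(C)c(-n2nncc2CN2C(=O)C3(C(C#N)=C(N)Oc4c3c3nc5ccccc5nc3c3ccccc43)c3ccccc32)c1` gives only a limit of the assay, > 50000 nM.
Compound 3 `N#CC1=C(N)Oc2c(N)cc3nc4ccccc4nc3c2C12C(=O)N(Cc1cnnn1-c1ccc(F)cc1)c1ccccc12` gives only a limit of the assay, > 50000 nM.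

Compound 3 thus stands at the limit of > 50000 nM in this assay, at which 2 of the 3 values shown sit, and has no number of its own. Compound 4 `Cc1ccc(Cl)cc1-n1nncc1CN1C(=O)C2(C(C#N)=C(N)Oc3c(N)cc4nc5ccccc5nc4c32)c2ccccc21` differs from it by 5-chloro-2-methylphenyl in place of 4-fluorophenyl on an aromatic nitrogen. Going by the values given here, the one measured step of comparable kind, a change of the aryl group on the same aromatic nitrogen, is an at least 1.6-fold higher number from compound 1 to compound 2 (0.20 log units; that floor lies within the scatter), which ends at a limit and gives no size beyond the scatter. Among the compounds with values here, no step from compound 3 itself is measured. The expected change is none beyond the scatter, a step that the limit leaves unreadable from compound 3 to compound 4, and compound 4 is expected most likely to return a limit again. Compound 4 is estimated at 70000 nM, within 30000 nM to 160000 nM.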

Compound 4, half-maximal inhibitory concentration: 37200 nM
Beside the measured number, compound 4's estimate is 1.9-fold (0.27 log units) above it, and the stated range covers the measured number.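

On the core of compound 3, the aryl group on the aromatic nitrogen can be changed with a number still obtained: in this assay, 5-chloro-2-methylphenyl in place of 4-fluorophenyl gives an at least 1.3-fold lower number from compound 3 to compound 4 (0.12 log units; that floor lies within the scatter). The true size of this step stays unreadable because compound 3 has only a limit and no number of its own: the limit of > 50000 nM in this assay, at which 2 of the 4 values shown sit.

Open, from the compounds shown here alone, is whether the chlorine or the methyl accounts for the number of compound 4. Also open, going by these compounds, is how a carboxylic acid or an amine on this phenyl ring would read on the same core.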